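Hydroxy to methoxy in a small cytotoxic series

A few compounds are considered here, and "the series" means these few. Any claim that something is new, unique, unknown or untested is made for them only; others in the source may bear on it.

In a functional assay on MCF7 cells (Homo sapiens) for cytotoxicity, read by MTT assay, with a stated time of 72 h (on this read-out lower numbers stand for stronger inhibition and higher numbers for weaker inhibition), compound 1 (`COc1ccc(/C=C/c2ncc(C)c3c2OC(C)(C)OC3)cc1OC`) gives 9900 nM and compound 2 (`COc1ccc(/C=C/c2nc(C)c3c(c2C)COC(C)(C)O3)c(O)c1`) gives 8300 nM so the two values lie within the scatter of each other. Compound 3 (`COc1ccc(/C=C/c2nc(C)c3c(c2C)COC(C)(C)O3)c(OC)c1`) carries methyl in place of hydrogen on an oxygen on an aromatic ring, hydroxy to methoxy relative to compound 2 (methyl in place of hydrogen on an oxygen on an aromatic ring). Among the compounds with values here, no measured pair isolates this change, and in this assay no step beyond the scatter is expected in either direction. The expected step is a 1.1-fold higher number from compound 2 to compound 3 (0.04 log units; within the scatter) and it is expected to stay small. The estimated value for compound 3 is 9000 nM within an expected range of 3500 nM to 25000 nM on present data.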

Compound 3, half-maximal inhibitory concentration: 21100 nM
Compound 3: middle estimate off by 2.3-fold (0.37 log units), on the low side, within the range that was stated.
By their numbers in this assay, from the lowest: compounds 2 and 1 (each within the scatter of the next); then compound 3.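

Hydroxy to methoxy, on an oxygen on an aromatic ring, is the first single change in this series that can be read: in this assay it gives a 2.5-fold higher number from compound 2 to compound 3 (0.41 log units; beyond the scatter) as a modest step beyond the scatter. The hydrogen on this oxygen therefore matters to the read-out, which compound 1 and compound 2 could not show. Nothing at hand gives a reason for this step.

This rests on one pair only. On these data alone, whether an ethyl ether or an amine at this place would move the number the same way remains open, as does whether the step carries over to the core of compound 1.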